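Ehrlich cell cytotoxicity: aryl variation at the saturated ring carbon

The source may report more compounds than this note shows. Statements on the series, on what has been measured and on what is new or still open speak of the compounds shown alone.

Measured compounds:
compound 1 `COc1cc(N2C(N)=C(C#N)C(c3ccc(OC)c4ccccc34)C3=C2CC(C)(C)CC3=O)cc(OC)c1OC`: 40%
compound 2 `COc1cc(N2C(N)=C(C#N)C(c3ccccc3Cl)C3=C2CC(C)(C)CC3=O)cc(OC)c1OC`: 20%
compound 3 `COc1cc(N2C(N)=C(C#N)C(c3ccccc3O)C3=C2CC(C)(C)CC3=O)cc(OC)c1OC`: 10%

In a functional assay on Ehrlich cells (Mus musculus) for cytotoxicity, tested at 100 ug/mL (a higher number here means a stronger effect of the compound at the concentration tested, a lower number a weaker effect), compound 1 gives 40%, the highest of the three numbers; the nearest is compound 2 and the furthest compound 3, both beyond the scatter. Compound 4 `COc1cc(N2C(N)=C(C#N)C(c3ccccc3)C3=C2CC(C)(C)CC3=O)cc(OC)c1OC` differs from compound 1 by phenyl in place of 4-methoxynaphthalen-1-yl on a saturated ring carbon. Both measured steps away from compound 1 exchange the same group for 2-chlorophenyl or 2-hydroxyphenyl and lower the read-out: a number 20 percentage points lower from compound 1 to compound 2 (beyond the scatter) and a number 30 percentage points lower from compound 1 to compound 3 (beyond the scatter). Between those two, a number 10 percentage points lower from compound 2 to compound 3 (within the scatter) stays within the scatter. A drop of similar size is therefore expected for compound 4, a number 20 percentage points lower from compound 1 to compound 4 (beyond the scatter). The estimate for compound 4 is 20%, with a range from 5% to 35%.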

Compound 4, a percentage reported as activity, at one concentration (the size of the read-out at that concentration, not a potency): 10%
Estimate against measurement, compound 4: 10 percentage points above; low and high end bracket the measured number.
By their numbers in this assay, from the lowest: compounds 3, 4 and 2 (each within the scatter of the next); then compound 1.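

The plain phenyl separates from the 4-methoxynaphthalen-1-yl in this assay, with a number 30 percentage points lower from compound 1 to compound 4 (beyond the scatter). Hydroxy and chloro on the phenyl do not separate from hydrogen, with no change at the digits printed from compound 3 to compound 4 (within the scatter) and a number 10 percentage points lower from compound 2 to compound 4 (within the scatter), so among these compounds only the 4-methoxynaphthalen-1-yl stands apart. Nothing available explains this gap.

The compounds shown leave open whether the second aromatic ring or the methoxy of that group carries the difference. A 4-methoxyphenyl or an unsubstituted naphthalen-1-yl on this saturated ring carbon would separate the two.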